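The source may report more compounds than this note shows. Statements on the series, on what has been measured and on what is new or still open speak of the compounds shown alone.

Measured so far:
Compound 1, `CN(C)Cc1ccc(-n2cc(-c3ccc4cc[nH]c4c3)c3c(Cl)ccnc32)cc1`, in an assay on isolated protein for inhibition of Myeloperoxidase (Homo sapiens); a higher number here means a weaker inhibitor, a lower number a stronger inhibitor: 120 nM
Compound 2, `NC(=O)CCn1cc(-c2ccc3cc[nH]c3c2)c(C(F)(F)F)n1`, in this assay: 4200 nM

Compound 2 stands at the higher of these two numbers, which means it is the weaker inhibitor of the pair. Among the compounds with values here, the only other compound, compound 1, sits far lower, and that gap lies well beyond the usual scatter of repeated measurements, so compound 2 is clearly the weaker of the two.

Compound 3, `N[C@@H]1CC[C@@H](n2cc(-c3ccc4cc[nH]c4c3)c(C(F)(F)F)n2)C1`, is built on the same core as compound 2 and differs from it in one place: a group of 6 heavy atoms (5 carbon, 1 nitrogen; one five-membered non-aromatic ring of carbon only) in place of a group of 5 heavy atoms (3 carbon, 1 nitrogen, 1 oxygen; no ring), on an aromatic nitrogen. Both groups carry one hydrogen-bond donor and one hydrogen-bond acceptor, but the new group brings a ring and two defined stereocentres where the old one was an open chain.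

Within the data shown here, no pair of measured compounds shows this kind of exchange, so there is no measured step to lean on. A change of this size on the ring nitrogen is expected to move the number only modestly, if at all, in this assay; the step from compound 2 to compound 3 is estimated as a 1.7-fold lower number from compound 2 to compound 3 (0.23 log units; within the scatter). Compound 3 is therefore expected to give about 2500 nM, within a range from 600 nM to 10000 nM.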

Compound 3, half-maximal inhibitory concentration: 70 nM
For compound 3 the middle estimate is 36-fold (1.55 log units) above the measured one; measured number outside the range, below it.
By their numbers in this assay, from the lowest: compounds 3 and 1 (each within the scatter of the next); then compound 2.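

In this assay, within the data shown here, the exchange on the aromatic nitrogen gives a 60-fold lower number from compound 2 to compound 3 (1.78 log units; beyond the scatter) and so shows that this position, for which no measured step existed before, can move the number by a large amount. The counts printed for the two groups do not separate them: each has one hydrogen-bond donor, one hydrogen-bond acceptor and no net charge, so the difference must lie in something else, such as the five-membered carbon ring, the two defined stereocentres or the loss of the 2-carbamoylethyl carbonyl. No measurement here explains why this exchange has so large an effect.

The compounds shown leave open which of these features carries the step, as all of them change together in this single pair. Going by these compounds, an open-chain aminopropyl group, a cyclopentyl ring with no nitrogen and the other stereoisomers of the new ring would each pull a different feature apart, and it also remains open whether the same exchange would act similarly on a different core.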